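Chloro in Place of Methyl at the Prostacyclin Receptor

The source may hold more compounds than are shown below. What is called first, only, known or untested is meant among the compounds shown, and "the series" means these compounds.

Compound 1 `Cc1ccc(CC(=O)O)cc1NC(=O)c1ccc(OC[C@@H]2CN(C)c3ccccc3O2)cc1Cl`: 1400 nM
Compound 2 `Cc1ccc(CC(=O)O)cc1NC(=O)c1cc(C)c(OC[C@@H]2CN(C)c3ccccc3O2)cc1C`: 2600 nM

In an assay on CHO cells for displacement of a labelled ligand from prostacyclin receptor (Homo sapiens), read by scintillation counting, with a stated time of 30 min (on this read-out lower numbers stand for stronger inhibition and higher numbers for weaker inhibition), compound 2 gives 2600 nM, the highest of the two numbers, yet within the scatter of compound 1, which gives 1400 nM. Compound 3 `Cc1cc(C(=O)Nc2cc(CC(=O)O)ccc2Cl)c(C)cc1OC[C@@H]1CN(C)c2ccccc2O1` differs from compound 2 by a single change, (chloro in place of methyl on an aromatic carbon), chloro in place of methyl on an aromatic carbon, para to a carboxymethyl group. Among the measured compounds shown here, no measured pair covers this change. The expected step in this assay is a 1.2-fold lower number from compound 2 to compound 3 (0.07 log units; within the scatter), with no clear direction and not beyond the scatter. Compound 3 is therefore estimated at 2200 nM, ranging from 700 nM to 7000 nM.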

Compound 3, inhibition constant: 1800 nM
Compound 3: middle estimate off by 1.2-fold (0.09 log units), on the high side; the range from low to high includes it.
By their numbers in this assay, from the lowest: compounds 1, 3 and 2 (each within the scatter of the next).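

Chloro in place of methyl on this aromatic carbon, para to a carboxymethyl group, gives a 1.4-fold lower number from compound 2 to compound 3 (0.16 log units; within the scatter) in this assay. Among the compounds shown here, this is the first measured pair for the change, and it shows that on this read-out the two groups cannot be told apart at this position. Nothing measured here bears on why they read alike.

Open, going by these compounds, is how a methoxy group, a nitrile or an amine would read at this position, and whether any group placed here would give a step beyond the scatter.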